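Trifluoromethyl for fluoro on an aromatic carbon

The compounds below may be only part of what the source reports. "The series", "measured", "known", "first", "only" and "open" are said of these compounds alone.

Two members of the series have been measured. Compound 1 `COCC(C(=O)N1CCN(c2cccc(C(F)(F)F)c2)CC1)N1C(=O)CCC1=O` gives in a functional assay on the whole organism (strain Swiss) with Mus musculus as the target, in the maximal electroshock model, with a stated time of 2 h, at a dose of 100 mg/kg by the intraperitoneal route (a higher number here means a stronger effect of the compound at the dose given, a lower number a weaker effect), a read-out of 0%. Compound 2 `CCC(C(=O)N1CCN(c2cccc(F)c2)CC1)N1C(=O)CCC1=O` gives in this assay an activity of 0%. Compound 2 thus stands level with compound 1 at the digits given; the two values lie within the scatter of each other, and no order between them can be stated.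

Compound 3 `CCC(C(=O)N1CCN(c2cccc(C(F)(F)F)c2)CC1)N1C(=O)CCC1=O` has not yet been measured in this assay. It differs from compound 2 in one place: trifluoromethyl in place of fluoro on an aromatic carbon. Compound 3 therefore carries the same aromatic substituent as compound 1 and the same chain as compound 2. Among the compounds with values here, no measured pair shows this step, so its size is not known from the data. Both neighbours of compound 3 show no activity, compound 1 with 0% and compound 2 with 0%. The expected step is no change at the digits printed from compound 2 to compound 3 (within the scatter), which is none beyond the scatter. Compound 3 is accordingly expected to give 0% in this assay, within a range from 0% to 10%.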

Compound 3, a percentage reported as activity, at one dose (the size of the read-out at that dose, not a potency): 0%
Compound 3: middle estimate and measured number agree at the digits printed; the measured number falls inside the stated range.
By their numbers in this assay, from the lowest: compounds 1, 2 and 3 (each within the scatter of the next).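

In this assay, trifluoromethyl in place of fluoro on the aromatic carbon gives no change at the digits printed from compound 2 to compound 3 (within the scatter), and methyl in place of methoxy on the saturated chain carbon gives no change at the digits printed from compound 1 to compound 3 (within the scatter). Within the data shown here, these are the first single-place steps that can be read, and compound 3, at 0%, shows that neither change at these two positions brings out activity at this dose and time. No supporting measurement bears on why the read-out stays the same.

As far as these compounds go, with all three compounds showing no activity, the read-out gives no way to rank these groups, and any difference between them that might appear under other conditions remains unknown. From the compounds shown here alone, it also remains open whether an amine in place of trifluoromethyl on the aromatic carbon, or a hydroxy group or a longer chain in place of methyl on the saturated chain carbon, would give a read-out beyond the scatter.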